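The compounds below may be only part of what the source reports. "The series", "measured", "known", "first", "only" and "open" are said of these compounds alone.

Going by the values given here, in an ADME assay on LLC-MK2 cells (Macaca mulatta) for cytotoxicity, read by spectrophotometry and crystal violet staining, with a stated time of 4 days (a lower number here means that less compound is tolerated, a higher number that more compound is tolerated), compound 1 `CC(C)n1ncc2c(C(=O)Nc3cccc(C(N)=O)c3)cc(-c3cccs3)nc21` gives 25000 nM, the only true number so far. Compound 2 `CC(C)n1ccc2c(C(=O)Nc3ccccn3)cc(-c3cccs3)nc21` reads > 200000 nM, which is a limit of the assay. Compound 3 `CC(C)n1ncc2c(C(=O)Nc3ccc(F)cc3)cc(-c3ccsc3)nc21` reads > 200000 nM, also a limit. Compound 4 `CC(C)n1ncc2c(C(=O)Nc3cncnc3)cc(-c3cccs3)nc21` has pyrimidin-5-yl in place of 3-carbamoylphenyl on an amide-type nitrogen. No single-point comparison between measured compounds is available to size this change. Of the measured compounds, only compound 1 carries 3-carbamoylphenyl, and the other two stand at the limit of > 200000 nM in this assay, at which 2 of the 3 values shown sit. They also differ from compound 1 elsewhere, so the expectation is loose. An upward move in this assay is expected, an estimated 3.6-fold higher number from compound 1 to compound 4 (0.56 log units; beyond the scatter). Compound 4 is expected at 90000 nM, with an estimated range of 30000 nM to 200000 nM.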

Compound 4, half-maximal cytotoxic concentration: 20000 nM
Compound 4: the middle estimate sits 4.5-fold (0.65 log units) above what was measured, outside the stated range (below it).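

In this assay, pyrimidin-5-yl in place of 3-carbamoylphenyl on an amide-type nitrogen gives a 1.3-fold lower number from compound 1 to compound 4 (0.10 log units; within the scatter), so this one-place exchange leaves the read-out within the scatter. At this position, then, the carbon-only ring and its hydrogen-bond donor can be exchanged for this ring with two hetero atoms without a readable change. Compound 2 and compound 3 remain limits, not numbers: the limit of > 200000 nM in this assay, at which 2 of the 4 values shown sit.

Their steps to compound 1 and compound 4 cannot be read. On these data alone, how a carboxylic acid or a morpholine on this amide-type nitrogen would read remains open.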